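Notes on adding chloro to compound 2

The compounds below may be only part of what the source reports. "The series", "measured", "known", "first", "only" and "open" are said of these compounds alone.

For the measured compounds named here, compound 1 `O=C(Nc1ccc(C(F)(F)F)cc1)c1cc(Cl)ccc1O` and compound 2 `O=C(Nc1ccc(C(F)(F)F)cc1)c1cc(Br)ccc1O` are the only compounds tested so far. In an ADME assay for permeability, using PAMPA (a higher number here means that the compound crosses the layer faster, a lower number that the compound crosses the layer more slowly), compound 1 gives < 22.3 10^-6 cm/s as a limit and not as a number. In this assay compound 2 gives "not determined" (no result reported) as its entry, so compound 2 has no single number to start from. The only reference in the series is compound 1, with the limit of < 22.3 10^-6 cm/s in this assay, at which 1 of the 2 values shown sits, as the whole of the measured evidence.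

Compound 3 `O=C(Nc1ccc(C(F)(F)F)c(Cl)c1)c1cc(Br)ccc1O` is still to be measured. The structural step chloro in place of hydrogen on an aromatic carbon puts chloro in place of hydrogen on an aromatic carbon, ortho to a trifluoromethyl group and meta to a large group. Going by the values given here, no measured pair shows what such a swap does. A step no larger than the usual scatter is therefore expected in this assay with no direction favoured. A further limit instead of a number is also quite possible. The expected value for compound 3 is 10 10^-6 cm/s within an estimated range from 2 10^-6 cm/s to 25 10^-6 cm/s in this read-out.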

Compound 3, apparent permeability: 23.2 10^-6 cm/s
Estimate against measurement, compound 3: 2.3-fold (0.37 log units) below, and the stated range covers the measured number.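

No step can be read from compound 2 to compound 3 in this assay: compound 2 has no single number there, so compound 3 at 23.2 10^-6 cm/s has no partner to be set against. The compounds shown leave open both the size and the direction of what chloro in place of hydrogen on an aromatic carbon, ortho to a trifluoromethyl group, does to this read-out.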